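Compound 3 to compound 4: 2-fluorobenzyl to 2-chlorobenzyl

The source may hold more compounds than are shown below. What is called first, only, known or untested is meant among the compounds shown, and "the series" means these compounds.

Measured in a functional assay on MCF7 cells (Homo sapiens) for antiproliferative activity, read by MTT assay, with a stated time of 48 h (on this read-out lower numbers stand for stronger inhibition and higher numbers for weaker inhibition), so far:
compound 1 `O=[N+]([O-])c1cc(C(F)(F)F)cc([N+](=O)[O-])c1Oc1ccc(Br)cc1/C=N\OCc1ccccc1F` gives 1120 nM
compound 2 `O=[N+]([O-])c1cc(C(F)(F)F)cc([N+](=O)[O-])c1Oc1c(Br)cc(Br)cc1/C=N\OCc1ccccc1` gives 1830 nM
compound 3 `O=[N+]([O-])c1cc(C(F)(F)F)cc([N+](=O)[O-])c1Oc1c(Br)cc(Br)cc1/C=N\OCc1ccccc1F` gives 880 nM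

Compound 3 stands level with its bromo-lacking neighbour within the scatter (a 1.3-fold lower number from compound 1 to compound 3 (0.10 log units; within the scatter)) and lower than its fluoro-lacking neighbour (a 2.1-fold lower number from compound 2 to compound 3 (0.32 log units; beyond the scatter)). The unmeasured compound 4 `O=[N+]([O-])c1cc(C(F)(F)F)cc([N+](=O)[O-])c1Oc1c(Br)cc(Br)cc1/C=N\OCc1ccccc1Cl` differs from compound 3 in one place (chloro in place of fluoro on an aromatic carbon), with chloro in place of fluoro on an aromatic carbon, ortho to a large group.

The closest evidence is the modest fluoro in place of hydrogen step (a 2.1-fold lower number from compound 2 to compound 3 (0.32 log units; beyond the scatter)), made at that same place. The bromo step (a 1.3-fold lower number from compound 1 to compound 3 (0.10 log units; within the scatter)) lies elsewhere and stays within the scatter. For the measured compounds named here, no chloro compound has been measured, so the case rests on a single step. In this assay no change beyond the scatter is therefore expected, and no direction is favoured. The expected step is small (a 1.0-fold higher number from compound 3 to compound 4 (0.01 log units; within the scatter)). For compound 4 the estimated value is 900 nM (expected range 450 nM to 1800 nM).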

Compound 4, half-maximal inhibitory concentration: 2320 nM
Estimate against measurement, compound 4: 2.6-fold (0.41 log units) below; the whole stated range lies below it.
By their numbers in this assay, from the lowest: compounds 3, 1, 2 and 4 (each within the scatter of the next, the first and the last beyond it).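

In this assay, the halogen at this place is not interchangeable: chloro in place of fluoro gives a 2.6-fold higher number from compound 3 to compound 4 (0.42 log units; beyond the scatter). Chloro in place of hydrogen gives a 1.3-fold higher number from compound 2 to compound 4 (0.10 log units; within the scatter), so compound 4 stands level with the unhalogenated benzyl compound 2, and the lower number seen with the 2-fluorobenzyl group in compound 3 is, among these compounds, confined to fluoro and does not extend to halogens at this place in general. No measurement at hand accounts for the difference between fluoro and chloro here.

Still open, on these data alone, is whether a methyl, a methoxy or an amine at this place would sit with compound 3 or with compounds 2 and 4. As far as these compounds go, it is also open whether the gap between fluoro and chloro holds on the core of compound 1, which carries one bromo fewer.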